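A few compounds are considered here, and "the series" means these few. Any claim that something is new, unique, unknown or untested is made for them only; others in the source may bear on it.

Working notes on the series. In an assay on microsomes from brain (strain Sprague-Dawley) for inhibition of heme oxygenase 2 (Rattus norvegicus), read by spectrophotometry, with a stated time of 60 min (on this read-out lower numbers stand for stronger inhibition and higher numbers for weaker inhibition), compound 1 `Clc1ccc2sc(SCCCCn3ccnc3)nc2c1` gives 900 nM, compound 2 `O=[N+]([O-])c1ccc(OCCCn2cncn2)cc1` gives 44700 nM, and compound 3 `O=[N+]([O-])c1ccc(OCCCn2ccnc2)cc1` gives 77600 nM. On these numbers compound 3 stands at the top, with compound 2 nearest (a 1.7-fold higher number from compound 2 to compound 3 (0.24 log units; within the scatter)) and compound 1, built on a different core, furthest away.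

Compound 4 `O=[N+]([O-])c1ccc(OCCCCn2cncn2)cc1` is not yet measured. It differs from compound 3 by (1H-1,2,4-triazol-1-yl)methyl in place of 1H-imidazol-1-yl on a saturated chain carbon, three bonds along the chain from an oxygen on an aromatic ring. For the measured compounds named here, the one measured step that bears on this is the exchange of the azole on the same core, from compound 2 to compound 3 (a 1.7-fold higher number from compound 2 to compound 3 (0.24 log units; within the scatter)), which stays within the scatter; the reverse exchange is therefore expected to move little. Going by the values given here, no measured step on this core shows the effect of a chain one carbon longer. The expected step is accordingly a 1.7-fold lower number from compound 3 to compound 4 (0.24 log units; within the scatter), a number no larger than the scatter and leaning toward the side of compound 2. Compound 4 is estimated at 45000 nM, with a range from 15000 nM to 130000 nM.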

Compound 4, half-maximal inhibitory concentration: 41700 nM
The estimate for compound 4 lay 1.1-fold (0.03 log units) above the measured number; low and high end bracket the measured number.
By their numbers in this assay, from the lowest: compound 1; then compounds 4, 2 and 3 (each within the scatter of the next).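

In this assay, for the compounds shown here, (1H-1,2,4-triazol-1-yl)methyl in place of 1H-1,2,4-triazol-1-yl gives a 1.1-fold lower number from compound 2 to compound 4 (0.03 log units; within the scatter) and so offers the first reading of chain length on the shared core, a change that stays within the scatter. The change of both azole and chain, (1H-1,2,4-triazol-1-yl)methyl in place of 1H-imidazol-1-yl, gives a 1.9-fold lower number from compound 3 to compound 4 (0.27 log units; within the scatter) and also stays within the scatter, so at this position on the shared core neither change separates compounds 2, 3 and 4.

Still open, on these data alone, is whether a longer chain at this position, or an amine in place of the nitro group on the shared core, would move the number beyond the scatter. Nothing available explains why these three numbers stay so close.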